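Acrylamide Growth Inhibitors: From a Methoxy to a Dichloro Arm

The source may hold more compounds than are shown below. What is called first, only, known or untested is meant among the compounds shown, and "the series" means these compounds.

Measured so far:
Compound 1, `N#C/C(=C\c1ccc(Cl)cc1)C(=O)c1ccc[nH]1`, 61000 nM
Compound 2, `COc1ccc(CNC(=O)/C(C#N)=C/c2ccc(Cl)o2)cc1`, 12000 nM
Compound 3, `COc1ccc(CNC(=O)/C(C#N)=C/c2cccc3ccccc23)cc1`, 16000 nM

All three were tested in a functional assay on DU-145 cells (Homo sapiens) for inhibition, read by MTT assay, with a stated time of 72 h; a lower number here means a stronger inhibitor of growth, a higher number a weaker inhibitor of growth. Compound 3 holds the second highest of the three numbers; compound 2 lies nearest, with a value within the scatter of that of compound 3, while compound 1 lies furthest, with a higher number beyond the scatter.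

Compound 4, `N#C/C(=C\c1cccc2ccccc12)C(=O)NCc1ccc(Cl)c(Cl)c1`, has not yet been measured. It differs from compound 3 in one place: 3,4-dichlorophenyl in place of 4-methoxyphenyl on a saturated chain carbon bound to an amide-type nitrogen. Within the data shown here, no step between two measured compounds describes this exchange, so the size of its effect in this assay is unknown. The expectation is a step of no size beyond the scatter, a 1.3-fold lower number from compound 3 to compound 4 (0.12 log units; within the scatter). Compound 4 is therefore estimated at 12000 nM, within a range from 4000 nM to 40000 nM.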

Compound 4, concentration for 50% growth inhibition: 12000 nM
Compound 4: the middle estimate sits on the measured number at the digits printed; the range from low to high includes it.
By their numbers in this assay, from the lowest: compounds 2, 4 and 3 (each within the scatter of the next); then compound 1.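

In this assay the exchange gives a 1.3-fold lower number from compound 3 to compound 4 (0.12 log units; within the scatter) as the first step read on a saturated chain carbon bound to an amide-type nitrogen. Among these compounds, at this place, 3,4-dichlorophenyl thus stands in for 4-methoxyphenyl with no change beyond the scatter, although the hydrogen-bond acceptor of the leaving group has no counterpart in the entering one. No measurement at hand bears on this result. The compounds shown leave open whether a plain phenyl, or a phenyl carrying an amine or a carboxylic acid, would hold the number at this place, and whether a longer chain would do so.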